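Methylsulfanyl in Place of Fluoro: What the Numbers Suggest

The compounds below may be only part of what the source reports. "The series", "measured", "known", "first", "only" and "open" are said of these compounds alone.

Compound 1 `Fc1ccc(C2=NN(C(=S)Nc3ccccc3)C(c3ccc4c(c3)OCCO4)C2)cc1`: 61200 nM
Compound 2 `S=C(Nc1ccccc1)N1N=C(c2ccc(Br)cc2)CC1c1ccc2c(c1)OCCO2`: 32100 nM

In a functional assay on HCT-116 cells (Homo sapiens) for antiproliferative activity, read by MTT assay, with a stated time of 48 h (a higher number here means a weaker inhibitor of growth, a lower number a stronger inhibitor of growth), compound 1 gives 61200 nM. Its nearest neighbour is compound 2, which in this assay gives 32100 nM. For the measured compounds named here, the only measured step that separates these two, a 1.9-fold lower number from compound 1 to compound 2 (0.28 log units; within the scatter), stays within the scatter, so compound 1 stands with one neighbour and no measured step that sets it apart.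

Compound 3 `CSc1ccc(C2=NN(C(=S)Nc3ccccc3)C(c3ccc4c(c3)OCCO4)C2)cc1` differs from compound 1 in one place: methylsulfanyl in place of fluoro on an aromatic carbon. Going by the values given here, no measured pair swaps fluoro for methylsulfanyl. Among the compounds with values here, the one step that bears on the change is the bromo swap at the same aromatic carbon, and it was small. On that basis the step is expected to be a 1.4-fold lower number from compound 1 to compound 3 (0.13 log units; within the scatter), with no shift beyond the scatter in either direction. Compound 3 is therefore estimated at 45000 nM, within a range of 15000 nM to 130000 nM.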

Compound 3, concentration for 50% growth inhibition: 193000 nM
Estimate against measurement, compound 3: 4.3-fold (0.63 log units) below; measured number above the stated range.
By their numbers in this assay, from the lowest: compounds 2 and 1 (each within the scatter of the next); then compound 3.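

In this assay, for the compounds shown here, methylsulfanyl gives the first change at this aromatic carbon to reach beyond the scatter: a 3.2-fold higher number from compound 1 to compound 3 (0.50 log units; beyond the scatter), and a 6.0-fold higher number from compound 2 to compound 3 (0.78 log units; beyond the scatter). The fluoro and bromo pair alone gave no sign that the group here matters, whereas compound 3 stands apart from both compound 1 and compound 2, on the side of weaker inhibition of growth. No measurement at hand accounts for this shift.

The compounds shown leave open whether the higher number goes with the sulfur or with the added methyl, a question on which a methoxy group or an ethylsulfanyl chain at this carbon would bear. Also open, as far as these compounds go, is how an amine at this carbon would read in this assay.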